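The source may hold more compounds than are shown below. What is called first, only, known or untested is meant among the compounds shown, and "the series" means these compounds.

Measured in a functional assay on HOS-TE85 cells (Homo sapiens) for inhibition, read by CCK-8 assay, with a stated time of 72 h; a higher number here means a weaker inhibitor, a lower number a stronger inhibitor:
- Compound 1 `Cc1ccnc(N2C(=O)CS[C@@H]2c2cccc(C(=O)NCCCCn3cccn3)c2)c1`: 21.9 nM
- Compound 2 `COc1ccc(OC)c(N2C(=O)CSC2c2cccc(C(=O)NCCCCc3ccccc3)c2)c1`: > 1000 nM, a limit of the assay and not a number

Compound 2 stands at the limit of > 1000 nM in this assay, at which 1 of the 2 values shown sits. Compound 1 is the only one of the two with an exact number, and it differs from compound 2 in more than one place, so no single structural change can be read from this pair.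

Among the measured compounds shown here, the next compound is compound 3 `CCN1C(=O)CSC1c1cccc(C(=O)NCCCCc2ccccc2)c1`, which changes only one group of compound 2. The change is ethyl in place of 2,5-dimethoxyphenyl on an amide-type nitrogen in a ring. For the measured compounds named here, no measured pair shows what this swap does on its own. The expectation therefore starts from compound 2, whose > 1000 nM is a limit. In this assay, compound 3 is expected to remain in the same region as compound 2, with no clear direction of change and no expected step beyond the scatter. The estimated step is a step that the limit leaves unreadable from compound 2 to compound 3. For compound 3 the expected value is 2000 nM, with an estimated range from 600 nM to 10000 nM.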

Compound 3, half-maximal inhibitory concentration: > 1000 nM
Compound 3 gave a limit, no number (the forecaster's own chance of this, stated with the estimate: 75%); the middle value is on the limit's open side.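

Compound 2 and compound 3 both give a limit and not a number, so no step can be read from compound 2 to compound 3: the limit of > 1000 nM in this assay, at which 2 of the 3 values shown sit.

The compounds shown leave open whether ethyl in place of 2,5-dimethoxyphenyl on the amide-type nitrogen in a ring changes inhibition at all, and by how much.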